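This account rests on a few compounds, and the source may have more. Where it says the series, first, only, none or still open, it means among the compounds named here.

Compound 1 `COc1ccc(-n2cc(COc3ccc(/C=C/C(=O)c4ccc5c(c4O)CCC(C)(C)O5)cc3)nn2)c([N+](=O)[O-])c1` gives 73100 nM in a functional assay on MCF7 cells (Homo sapiens) for antiproliferative activity, read by MTT assay; a lower number here means a stronger inhibitor, a higher number a weaker inhibitor. Among the measured compounds shown here, that is the only number in this small set, so it cannot be ranked against anything. Compound 2 `CCCCCn1cc(COc2ccc(/C=C/C(=O)c3cc4c(cc3O)OC(C)(C)CC4)cc2)nn1` is recorded as "not active" (no number reported), and compound 3 `CCCCCCCCn1cc(COc2ccc(/C=C/C(=O)c3cc4c(cc3O)OC(C)(C)CC4)cc2)nn1` is also recorded as "not active" (no number reported); neither entry carries a figure.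

The next compound to be tested is compound 4 `CCCCCn1cc(COc2ccc(/C=C/C(=O)c3ccc4c(c3O)CCC(C)(C)O4)cc2)nn1`. It keeps the core of compound 1 but has pentyl in place of 4-methoxy-2-nitrophenyl on an aromatic nitrogen. For the measured compounds named here, no measured pair in the set shows what such an exchange does, so the expectation rests on little. With compound 1 at 73100 nM as the sole anchor, no step beyond the scatter is expected in either direction, and a result with no number remains a real possibility given the entry for compound 2 at "not active" (no number reported). The estimated change is a 1.2-fold lower number from compound 1 to compound 4 (0.09 log units; within the scatter). For compound 4 the expected value in this assay is 60000 nM, with an estimated range of 20000 nM to 180000 nM.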

Compound 4, half-maximal inhibitory concentration: 191000 nM
The estimate for compound 4 lay 3.2-fold (0.50 log units) below the measured number, outside the stated range (above it).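

In this assay, among the compounds shown here, the exchange of 4-methoxy-2-nitrophenyl for pentyl on the aromatic nitrogen gives a 2.6-fold higher number from compound 1 to compound 4 (0.42 log units; beyond the scatter) and is the first measured step in this set, showing that the number at this position changes with the group it carries, though only modestly. Both compounds give numbers on the same core, so a pentyl chain here does not abolish measurable activity, and the aromatic group gives the lower number of the two. Nothing measured in this set accounts for the step.

For the compounds shown here, the single pair cannot separate the contribution of the methoxy group from that of the nitro group, nor show whether the ring itself matters. A plain phenyl ring would begin to settle that, and a chain carrying a carboxylic acid would show whether this position tolerates a very different end group.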